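Fluoro on Two Different Rings in a Piperazine Series

This account rests on a few compounds, and the source may have more. Where it says the series, first, only, none or still open, it means among the compounds named here.

In a functional assay on the whole organism for inhibition, with Mus musculus as the target, at a dose of 25 mg/kg by the oral route (on this read-out lower numbers stand for less inhibition and higher numbers for more inhibition at the one dose given (going by the name of the read-out)), the three measured compounds gave the following read-outs:

compound 1 `c1ccc(N2CCN(CCCCOc3ccc4c(c3)CCC4)CC2)cc1`: 50%
compound 2 `c1ccc(N2CCN(CCCCCOc3ccc4c(c3)CCC4)CC2)cc1`: 25%
compound 3 `Fc1ccc(N2CCN(CCCCCOc3ccc4c(c3)CCC4)CC2)cc1`: 71%

Compound 2 and compound 3 differ in one place, (fluoro in place of hydrogen on an aromatic carbon), and this single change gave a number 46 percentage points higher from compound 2 to compound 3 (beyond the scatter). Compound 1 and compound 2 share a related core, but the difference between the two cores is not broken down here; their values show compound 1 higher than compound 2 beyond the scatter, and compound 3 higher than compound 1 beyond the scatter.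

Compound 4 `Fc1cc2c(cc1OCCCCN1CCN(c3ccccc3)CC1)CCC2` is not yet measured. It differs from compound 1 by fluoro in place of hydrogen on an aromatic carbon. This is the same kind of change as between compound 2 and compound 3, but not the same: there the fluoro sits para to a large group on a plain ring, whereas here it sits ortho to a large group, meta to a fused ring and para to a fused ring, within a fused system of two rings.

Within the data shown here, because the one measured instance of this kind of change was a number 46 percentage points higher from compound 2 to compound 3 (beyond the scatter), yet at a different place, a smaller upward step is expected, estimated as a number 10 percentage points higher from compound 1 to compound 4 (within the scatter). Compound 4 is therefore expected to give about 60%, within roughly 35% to 85%, in this assay.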

Compound 4, a percentage reported as inhibition, in the whole organism at one dose (the size of the read-out at that dose, not a potency): 79%
Compound 4: middle estimate off by 19 percentage points, on the low side; the measured number falls inside the stated range.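

In this assay, fluoro in place of hydrogen on an aromatic carbon gave a number 29 percentage points higher from compound 1 to compound 4 (beyond the scatter), so the upward direction seen on the other core also appeared on the core of compound 1. The size of the step did not carry over, as the two instances stand apart: the same change on two cores in this assay, a number 46 percentage points higher (beyond the scatter) from compound 2 to compound 3 and a number 29 percentage points higher (beyond the scatter) from compound 1 to compound 4, 17 percentage points apart, beyond the scatter of two such steps. With only two instances, differing both in the core and in the ring that carries the fluoro, these results cannot show which of the two differences goes with the gap, nor whether the direction would hold on any further core.

The compounds shown leave open what each core would give with fluoro on the other ring, and whether fluoro on both rings of one compound would add to the read-out. They also leave open whether chloro or methoxy in place of the fluoro would give a step of similar direction and size.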